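A few compounds are considered here, and "the series" means these few. Any claim that something is new, unique, unknown or untested is made for them only; others in the source may bear on it.

Within the data shown here, in a functional assay on HCT-116 cells (Homo sapiens) for inhibition, read by CCK-8 assay, with a stated time of 72 h, tested at 2 uM (a lower number here means less inhibition of growth, a higher number more inhibition of growth at the concentration tested), compound 1 (`Cc1ccc(SCc2ccc(C(=O)Nc3ccccc3N)cc2)cc1`) gives 74.8% and holds the higher of the two numbers known so far. Compound 2 (`Nc1ccccc1NC(=O)c1ccc(CSc2ccc(C(F)(F)F)cn2)cc1`) gives 1.2% in this assay and lies below compound 1 by a gap well beyond the scatter. Compound 3 (`Nc1ccccc1NC(=O)c1ccc(CSc2ccc(F)cc2)cc1`) has not yet been measured. It keeps the core of compound 1 and alters one group, on an aromatic carbon of a six-membered aromatic ring of carbon only, para to a large group. There, 4-methylphenyl becomes 4-fluorophenyl, with fluoro in place of methyl (fluoro in place of methyl on an aromatic carbon). Among the measured compounds shown here, no measured pair of compounds differing in one place is available to size such a change. For the measured compounds named here, the expectation therefore starts from compound 1 at 74.8% and from the fact that only this one group is exchanged. A modest fall in this assay is expected, possibly none beyond the scatter, with an estimated step of a number 12.8 percentage points lower from compound 1 to compound 3 (beyond the scatter) as the working figure. The estimated value for compound 3 is 62% with an expected range from 35% to 82% in this assay.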

Compound 3, percent growth inhibition at one concentration: 13.5%
For compound 3 the middle estimate is 48.5 percentage points above the measured one, and the stated range ends above it.
By their numbers in this assay, from the lowest: compound 2; then compound 3; then compound 1.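

The exchange of methyl for fluoro on an aromatic carbon, para to a large group, replaces one heavy atom with one heavy atom, and no ring, hydrogen-bond donor, hydrogen-bond acceptor or net charge enters or leaves. Even so, this single exchange in this assay gives a number 61.3 percentage points lower from compound 1 to compound 3 (beyond the scatter); as the first measured pair differing in one place, it shows that this position is not indifferent to the group it carries, and that fluoro does not stand in for methyl here at the concentration tested. Nothing available explains why so small a count of changed atoms goes with a step of this size.

The compounds shown leave open what an ethyl group, a methoxy group, a chloro group or an amine would give on this same aromatic carbon, and so whether methyl is a rare good fit or one of many groups that would serve. They also leave open whether the step seen at this one concentration reflects a shift in the full concentration response of compound 3 or only its position at that single point.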